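A Succinate Ester and a Nitroxide Amide, Reconsidered

The source may report more compounds than this note shows. Statements on the series, on what has been measured and on what is new or still open speak of the compounds shown alone.

Compound 1, `Cc1c(C)c2c(c(C)c1O)CCC(C)(C(=O)NC1CC(C)(C)N([O])C(C)(C)C1)O2`: 39000 nM
Compound 2, `Cc1c(C)c2c(c(C)c1OC(=O)CCC(=O)O)CCC(C)(C(=O)NC1CC(C)(C)N([O])C(C)(C)C1)O2`: > 300000 nM (a limit)
Compound 3, `Cc1c(C)c2c(c(C)c1OC(=O)CCC(=O)NC1CC(C)(C)N([O])C1(C)C)CCC(C)(C(=O)NC1CC(C)(C)N([O])C1(C)C)O2`: > 300000 nM (a limit)
Compound 4, `Cc1c(C)c2c(c(C)c1OC(=O)CCC(=O)O)CCC(C)(C(=O)NC1CC(C)(C)N([O])C1(C)C)O2`: not yet measured

In a functional assay on RPMI-8226 cells (Homo sapiens) for cytotoxicity, read by MTT assay, with a stated time of 72 h (a lower number here means a stronger inhibitor, a higher number a weaker inhibitor), compound 1 gives 39000 nM. For compound 2 the value > 300000 nM is a limit of the assay, not a number. For compound 3 the value > 300000 nM is likewise a limit, so compound 3 stands at the limit of > 300000 nM in this assay, at which 2 of the 3 values shown sit, rather than at a measured point. Compound 4 arises from compound 3 by one oxygen atom in place of a group of 11 heavy atoms (8 carbon, 2 nitrogen, 1 oxygen; one five-membered non-aromatic ring with 1 hetero atom), on a carbonyl carbon. Going by the values given here, the one measured step, an at least 7.6-fold higher number from compound 1 to compound 2 (0.88 log units; beyond the scatter), shows the (2-carboxyethyl)carbonyl ester weakening inhibition already; compound 2 and compound 3 both sit at the same limit. Compound 4 is therefore expected to remain at or beyond that limit, with a step that the limit leaves unreadable from compound 3 to compound 4 as the estimated step. For compound 4 the expected value is 400000 nM, between 150000 nM and 1500000 nM.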

Compound 4, half-maximal inhibitory concentration: > 300000 nM
Compound 4: no number, only a limit; the forecaster's own chance of this, stated with the estimate: 85%; the middle value is on the limit's open side.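

In this assay compound 4 gives > 300000 nM, a limit and not a number, so the steps from compound 2 and compound 3 to compound 4 cannot be read. From the compounds shown here alone, what stays open is whether the five-membered and six-membered ring groups on the amide-type nitrogen differ at all in this assay.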